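The source may hold more compounds than are shown below. What is called first, only, known or untested is meant among the compounds shown, and "the series" means these compounds.

In a functional assay on A549 cells (Homo sapiens) for antiproliferative activity, read by MTT assay, with a stated time of 72 h (a higher number here means a weaker inhibitor, a lower number a stronger inhibitor), three compounds share one core and differ only in the chloro groups on their phenyl ring. Compound 1 `NC1=NC2(CCOCC2)N(OCCCOc2ccc(Cl)cc2)C(N)=N1` gives 360 nM, compound 2 `NC1=NC2(CCOCC2)N(OCCCOc2ccccc2Cl)C(N)=N1` gives 2700 nM, and compound 3 `NC1=NC2(CCOCC2)N(OCCCOc2ccc(Cl)cc2Cl)C(N)=N1` gives 70 nM, the lowest of the three numbers. Compound 4 `NC1=NC2(CCOCC2)N(OCCCOc2cc(Cl)c(Cl)cc2Cl)C(N)=N1` alters compound 3 in one place: chloro in place of hydrogen on an aromatic carbon, turning 2,4-dichlorophenyl into 2,4,5-trichlorophenyl. Two measured steps also put chloro in place of hydrogen on an aromatic carbon, though not at this new place: a 5.1-fold lower number from compound 1 to compound 3 (0.71 log units; beyond the scatter) and a 39-fold lower number from compound 2 to compound 3 (1.59 log units; beyond the scatter). Both lowered the number, so a modest further fall is expected in this assay, with the expected step being a 2.0-fold lower number from compound 3 to compound 4 (0.30 log units; within the scatter). For compound 4 the estimated value is 35 nM, within an expected range of 10 nM to 130 nM.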

Compound 4, half-maximal inhibitory concentration: 680 nM
Compound 4: middle estimate off by 19-fold (1.29 log units), on the low side; the whole stated range lies below it.
By their numbers in this assay, from the lowest: compound 3; then compounds 1 and 4 (each within the scatter of the next); then compound 2.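

Chloro in place of hydrogen does not always lower the number on this ring: at the new place, ortho to one chloro group and para to another, this assay shows a 9.7-fold higher number from compound 3 to compound 4 (0.99 log units; beyond the scatter) instead of a further fall. Even so, the change to 2,4,5-trichlorophenyl gives a 4.0-fold lower number from compound 2 to compound 4 (0.60 log units; beyond the scatter) and, within the scatter, a 1.9-fold higher number from compound 1 to compound 4 (0.28 log units; within the scatter) as well. No measurement here explains the reversal.

Still open, going by these compounds, is whether this place turns against any added group or against chloro alone. A methyl or a methoxy group on the same carbon would separate those two readings.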